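This account rests on a few compounds, and the source may have more. Where it says the series, first, only, none or still open, it means among the compounds named here.

Two measured compounds open the series. Compound 1, with the structure `Nc1nnc(SCc2cc(=O)c3cc(Cl)ccc3o2)s1`, carries an amino group on its five-membered ring. In a functional assay on HEp-2 cells (Homo sapiens) for cytotoxicity, read by MTT assay, with a stated time of 72 h (on this read-out lower numbers stand for stronger inhibition and higher numbers for weaker inhibition), compound 1 gives > 25000 nM, which is a limit of the assay rather than a number. Compound 2, with the structure `Cc1ccc2oc(CSc3nnc(C)s3)cc(=O)c2c1`, carries a methyl group on that ring instead and a methyl group on its shared core. In this assay compound 2 gives > 25000 nM, again a limit of the assay and not a number. So compound 2 stands at the edge of what the assay can report, and no ordering between compound 1 and compound 2 can be read from these two limits.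

Compound 3, with the structure `Cc1ccc2oc(CSc3nnc(N)s3)cc(=O)c2c1`, is not yet measured. It differs from compound 2 in one place: amino in place of methyl on an aromatic carbon. Because (the limit of > 25000 nM in this assay, at which 2 of the 2 values shown sit), the expectation for this step is that nothing beyond the scatter will appear, and that the assay will most likely again report only a limit. The step from compound 2 to compound 3 is therefore expected to be a step that the limit leaves unreadable from compound 2 to compound 3. For compound 3 the estimate in this assay is 40000 nM, within a range from 15000 nM to 150000 nM.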

Compound 3, half-maximal inhibitory concentration: > 25000 nM
Compound 3: only a limit was reported (the forecaster's own chance of this, stated with the estimate: 85%); the middle value lies beyond the limit too.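

In this assay compound 3 gives > 25000 nM as a limit of the assay and not a number. Among the compounds shown here, no step from compound 1 or compound 2 to compound 3 can be read, since all three stop at the same point: the limit of > 25000 nM in this assay, at which 3 of the 3 values shown sit. The compounds shown leave open whether amino in place of methyl, or methyl in place of chloro, changes the cytotoxicity at all.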